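This account rests on a few compounds, and the source may have more. Where it says the series, first, only, none or still open, it means among the compounds named here.

Measured in a functional assay on HepG2 cells (Homo sapiens) for cytotoxicity, read by MTT assay, with a stated time of 72 h; on this read-out lower numbers stand for stronger inhibition and higher numbers for weaker inhibition:
- compound 1 `CN1CCN(c2ccc(Nc3ncc4nc(Nc5ccccc5)n(C5CCCCC5)c4n3)cc2)CC1`: > 5000 nM (a limit of the assay, not a number)
- compound 2 `CN1CCN(c2ccc(Nc3ncc4nc(Nc5cccc(Cl)c5)n(C5CCCC5)c4n3)cc2)CC1`: 4800 nM

Among the measured compounds shown here, compound 2 holds the only number so far. Compound 1 is known only through its limit, so no step can be read from the pair.

Compound 3 `CN1CCN(c2ccc(Nc3ncc4nc(Nc5cc(Cl)ccc5Cl)n(C5CCCC5)c4n3)cc2)CC1` is not yet measured. It has chloro in place of hydrogen on an aromatic carbon, ortho to a large group and para to a chloro group, turning 3-chlorophenyl into 2,5-dichlorophenyl (chloro in place of hydrogen on an aromatic carbon). For the measured compounds named here, no measured step covers this change, so only a small step in this assay is expected, with no firm direction and probably none beyond the scatter. The expected change is a 1.2-fold lower number from compound 2 to compound 3 (0.08 log units; within the scatter). A limit rather than a number is also a real possibility. The estimate for compound 3 is 4000 nM, with an expected range of 1500 nM to 7000 nM.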

Compound 3, half-maximal inhibitory concentration: > 5000 nM
Compound 3: no number, only a limit; the forecaster's own chance of this, stated with the estimate: 40%; at least 1.2-fold (0.09 log units) between middle value and limit.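

In this assay compound 3 gives > 5000 nM, a limit of the assay and not a number. Among the compounds shown here, this is the first step the series offers: chloro in place of hydrogen on an aromatic carbon, ortho to a large group and para to a chloro group, gives an at least 1.0-fold higher number from compound 2 to compound 3 (0.01 log units; that floor lies within the scatter), so 2,5-dichlorophenyl brings no measured number lower than that of 3-chlorophenyl, and the true size of the step stays unknown. What can be read here is bounded by a single limit: the limit of > 5000 nM in this assay, at which 2 of the 3 values shown sit.

Going by these compounds, whether an amine, a methoxy group or a carboxylic acid at this position would give a number inside the range of the assay remains open. Also open, on these data alone, is how the 3-chlorophenyl compound would read with its chloro replaced by hydrogen, with the cyclopentyl group kept.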